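Amidoxime to ethoxy-amidine: a step in oral bioavailability

The compounds below may be only part of what the source reports. "The series", "measured", "known", "first", "only" and "open" are said of these compounds alone.

Compound 1 `N=C(N)c1ccc2[nH]c(-c3cccc(-c4cc(F)ccc4O)c3O)cc2c1` reaches only the limit of < 1% in an in vivo ADME assay on the whole organism (strain Sprague-Dawley) for pharmacokinetics, with Rattus norvegicus as the target (on this read-out lower numbers stand for lower oral bioavailability and higher numbers for higher oral bioavailability), so no number is known for it. Among the measured compounds shown here, compound 2 `N/C(=N/O)c1ccc2[nH]c(-c3cccc(-c4ccccc4O)c3O)cc2c1` gives 15% in this assay, the only actual number in the set. The other value, that of compound 1, sits at a limit, as noted by the limit of < 1% in this assay, at which 1 of the 2 values shown sits. Compound 3 `CCONC(=N)c1ccc2[nH]c(-c3cccc(-c4ccccc4O)c3O)cc2c1` differs from compound 2 by a group of 6 heavy atoms (3 carbon, 2 nitrogen, 1 oxygen; no ring) in place of a group of 4 heavy atoms (1 carbon, 2 nitrogen, 1 oxygen; no ring), on an aromatic carbon. For the measured compounds named here, with no measured step of this kind available, the change is expected to raise oral bioavailability beyond the scatter, by a number 15 percentage points higher from compound 2 to compound 3 (beyond the scatter). Compound 3 is therefore estimated at 30%, between 10% and 60%.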

Compound 3, oral bioavailability: 67%
Compound 3: the middle estimate sits 37 percentage points below what was measured; measured number above the stated range.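

In this assay, among the compounds shown here, the group on this aromatic carbon proves to matter: replacing the amidoxime with the ethoxy-amidine gives a number 52 percentage points higher from compound 2 to compound 3 (beyond the scatter), a change the earlier compounds could not show. The two groups have the same counts of hydrogen-bond donors and acceptors, so those counts do not separate them. Nothing shown here accounts for the step.

The compounds shown leave open how a methoxy group or a longer chain, such as propoxy, on that oxygen would compare. As far as these compounds go, whether a carboxylic acid on this carbon would fit the same trend also stays open.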